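Methyl to Nitro: Expecting Compound 4

The source may report more compounds than this note shows. Statements on the series, on what has been measured and on what is new or still open speak of the compounds shown alone.

Three compounds share one core and differ only in the group carried on an aromatic carbon. Compound 1 `O=C1NC(=O)/C(=C/c2ccc(OCCSc3nnc(-c4ccccc4)[nH]3)cc2)S1` gives 19.2% in a functional assay on the whole organism (strain Wistar) with Rattus norvegicus as the target, with a stated time of 15 days, at a dose of 10 mg/kg by the oral route; a lower number here means a weaker effect, a higher number a stronger effect of the compound at the dose given. Compound 2 `O=C1NC(=O)/C(=C/c2ccc(OCCSc3nnc(Cc4ccccc4)[nH]3)cc2)S1` gives 22.8%, and compound 3 `Cc1ccc(-c2nnc(SCCOc3ccc(/C=C4\SC(=O)NC4=O)cc3)[nH]2)cc1` gives 21.7%; compound 3 thus stands second highest of the three, though every gap lies within the scatter: a number 3.6 percentage points higher from compound 1 to compound 2 (within the scatter), a number 2.5 percentage points higher from compound 1 to compound 3 (within the scatter) and a number 1.1 percentage points lower from compound 2 to compound 3 (within the scatter). Compound 4 `O=C1NC(=O)/C(=C/c2ccc(OCCSc3nnc(-c4ccc([N+](=O)[O-])cc4)[nH]3)cc2)S1` differs from compound 3 by nitro in place of methyl on an aromatic carbon. The closest guide is the change from compound 1 to compound 3, which put methyl in place of hydrogen on the same aromatic carbon and moved nothing beyond the scatter. Compound 4 is therefore expected to show a number 0.3 percentage points higher from compound 3 to compound 4 (within the scatter). Compound 4 is estimated at 22%, between 12% and 32%.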

Compound 4, a percentage reported as activity, at one dose (the size of the read-out at that dose, not a potency): 15.3%
Compound 4: the middle estimate sits 6.7 percentage points above what was measured, within the range that was stated.
By their numbers in this assay, from the lowest: compounds 4, 1, 3 and 2 (each within the scatter of the next).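

Nitro at this aromatic carbon brings two hydrogen-bond acceptors that methyl lacks, yet the read-out in this assay does not leave the scatter (a number 6.4 percentage points lower from compound 3 to compound 4 (within the scatter)). The same holds for nitro in place of hydrogen (a number 3.9 percentage points lower from compound 1 to compound 4 (within the scatter)) and for 4-nitrophenyl in place of benzyl (a number 7.5 percentage points lower from compound 2 to compound 4 (within the scatter)). Hydrogen, methyl and nitro at this position therefore cannot be told apart in this series. Nothing available here bears on the reason for this result. Going by these compounds, whether an amine, a carboxylic acid or a longer chain at this carbon would produce a step beyond the scatter remains open.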